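Swapping Nitro for Chloro on a Weak Growth Inhibitor

The compounds below may be only part of what the source reports. "The series", "measured", "known", "first", "only" and "open" are said of these compounds alone.

Of the compounds shown here, two have been tested in a functional assay on U-251 cells (Homo sapiens) for inhibition, read by MTT assay, with a stated time of 2 days; a higher number here means a weaker inhibitor of growth, a lower number a stronger inhibitor of growth. Compound 1 `COc1ccc(NC(=O)CNc2ccc(C(=O)Nc3ccccc3N)cc2)cc1` gives 25500 nM in this assay. Compound 2 `Nc1ccccc1NC(=O)CCCNCC(=O)Nc1cccc([N+](=O)[O-])c1` gives 15000 nM in this assay. These two numbers lie within the scatter of repeated measurements of each other, so neither compound can be called the stronger inhibitor of growth; both sit in the weak range, and compound 2 simply carries the lower of the two numbers shown.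

Compound 3 `Nc1ccccc1NC(=O)CCCNCC(=O)Nc1cccc(Cl)c1` has not yet been measured. It differs from compound 2 in one place: chloro in place of nitro on an aromatic carbon. Among the measured compounds shown here, no measured pair shows what this particular exchange does, so the expectation must rest on compound 2 alone, whose value of 15000 nM is the only anchor.

With nothing pointing either way, the step from compound 2 to compound 3 is expected to be small, no change at the digits printed from compound 2 to compound 3 (within the scatter), and not clearly beyond the scatter in either direction. Compound 3 is therefore estimated to give about 15000 nM in this assay, with a likely range from 5000 nM to 45000 nM.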

Compound 3, concentration for 50% growth inhibition: 19500 nM
Estimate against measurement, compound 3: 1.3-fold (0.11 log units) below, within the range that was stated.
By their numbers in this assay, from the lowest: compounds 2, 3 and 1 (each within the scatter of the next).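

In this assay the read-out shows a 1.3-fold higher number from compound 2 to compound 3 (0.11 log units; within the scatter) when chloro takes the place of nitro on this aromatic carbon. Among the compounds shown here, this is the first direct reading of a change at this place, as compound 1 differs from compound 2 in more than one place, and it shows that a nitro group, with three heavy atoms and two hydrogen-bond acceptors, can give way to a single chlorine with no hydrogen-bond acceptors without a shift that can be told apart from ordinary repeat-to-repeat variation. No measurement available here explains why the two numbers stay so close, so the result stands as an observation only.

Two groups at one place are a narrow sample, and they cannot show whether this spot is generally tolerant of change or whether these two groups merely happen to read alike. Going by these compounds, what an amine or a carboxylic acid on the same aromatic carbon would do remains open, as does whether a longer chain in the part of the molecule shared by compound 2 and compound 3 would move the number further than this exchange did.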